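This account rests on a few compounds, and the source may have more. Where it says the series, first, only, none or still open, it means among the compounds named here.

Measured compounds:
Compound 1 is `COc1ccc(/C=C/C(=O)c2sc(Nc3ccc(Cl)cc3)nc2C)cc1` and gives > 25000 nM in a functional assay on PC-3 cells (Homo sapiens) for cytotoxicity, read by MTT assay; a lower number here means a stronger inhibitor, a higher number a weaker inhibitor.
Compound 2 is `Cc1nc(Nc2ccc(Cl)c(Cl)c2)sc1C(=O)/C=C/c1ccc(Cl)cc1` and gives > 25000 nM in this assay.
Compound 3 is `COc1ccc(/C=C/C(=O)c2sc(Nc3ccc(Cl)c(Cl)c3)nc2C)cc1` and has not yet been measured in this assay.

Compound 2 stands at a limit of the assay rather than at a number: in this assay compound 2 gives > 25000 nM, which is a limit. Compound 1 likewise reaches only a limit, its value in this assay being > 25000 nM. Neither of the two measured values is a number that could be set in order against the other, since both sit at the same limit (the limit of > 25000 nM in this assay, at which 2 of the 2 values shown sit).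

Compound 3 differs from compound 2 in one place: methoxy in place of chloro on an aromatic carbon. Compound 1 already carries this methoxy group and shares the rest of its structure with compound 3 except for the anilino part. With both neighbours of compound 3 at the limit, the step from compound 2 to compound 3 is expected to be a step that the limit leaves unreadable from compound 2 to compound 3, that is, no movement beyond the scatter that the data could reveal. Compound 3 is therefore expected to give about 30000 nM in this assay, within a range from 10000 nM to 100000 nM, and most likely again only a limit.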

Compound 3, half-maximal inhibitory concentration: > 25000 nM
Compound 3 ended at the assay's limit (the forecaster's own chance of this, stated with the estimate: 85%); the middle value does not contradict the limit.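

Neither the step from compound 2 to compound 3 nor the step from compound 1 to compound 3 can be read, because all three compounds stand at one limit: the limit of > 25000 nM in this assay, at which 3 of the 3 values shown sit.

The compounds shown leave open how strong any of the three actually is, and whether either the methoxy-for-chloro or the chloro-for-hydrogen change makes any difference.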